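From an Ethoxy to an Allyloxy Side Chain

The compounds below may be only part of what the source reports. "The series", "measured", "known", "first", "only" and "open" are said of these compounds alone.

Two measured compounds share one core and differ only in the group on the saturated chain carbon bound to an oxygen on the aromatic ring. Compound 1 `CN(C)CCCNc1ccnc2cc(OCc3ccc(F)cc3)ccc12` carries a 4-fluorophenyl there, and in a functional assay on HepG2 cells (Homo sapiens) for cytotoxicity, read by MTT assay, with a stated time of 48 h (on this read-out higher numbers stand for weaker inhibition and lower numbers for stronger inhibition), compound 1 gives 1570 nM. Compound 2 `CCOc1ccc2c(NCCCN(C)C)ccnc2c1` carries a methyl instead, and in this assay compound 2 gives 5860 nM, the higher of the two numbers. Within the data shown here, the step of a 3.7-fold higher number from compound 1 to compound 2 (0.57 log units; beyond the scatter) is the only measured step that bears on the next change, and it runs toward a higher number as the group shrinks from 4-fluorophenyl to methyl.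

Compound 3 `C=CCOc1ccc2c(NCCCN(C)C)ccnc2c1` is not yet measured. It differs from compound 2 by vinyl in place of methyl on a saturated chain carbon bound to an oxygen on an aromatic ring; read one bond further out, ethyl becomes allyl and ethoxy becomes allyloxy. Among the measured compounds shown here, the enlargement here is far smaller than the one separating compound 1 from compound 2, so only a small movement toward a lower number, possibly within the scatter, seems likely. Compound 3 is therefore expected to give 4000 nM in this assay, with a range from 1800 nM to 9000 nM. The expected step of a 1.5-fold lower number from compound 2 to compound 3 (0.17 log units; within the scatter) is a modest one.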

Compound 3, half-maximal inhibitory concentration: 3990 nM
Estimate against measurement, compound 3: 1.0-fold (0.00 log units) above; measured number inside the range.
By their numbers in this assay, from the lowest: compound 1; then compounds 3 and 2 (each within the scatter of the next).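

Replacing methyl with vinyl on a saturated chain carbon bound to an oxygen on an aromatic ring gives, in this assay, a 1.5-fold lower number from compound 2 to compound 3 (0.17 log units; within the scatter), so this small extension and its double bond produce no difference that can be separated from ordinary assay scatter. The second comparison, with 4-fluorophenyl in the same place, gives a 2.5-fold higher number from compound 1 to compound 3 (0.41 log units; beyond the scatter) in this assay, which shows that the separation of compound 1 from compound 2 also holds for compound 3 and does not depend on methyl being the small group. No supporting measurement is available to explain either comparison.

The compounds shown do not tell whether the lower number of compound 1 goes with the ring itself or with its fluorine, a question that a plain phenyl in the same place would address. They also leave open how the number would respond to a longer chain, an amine or a carboxylic acid at this position.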